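This account rests on a few compounds, and the source may have more. Where it says the series, first, only, none or still open, it means among the compounds named here.

Of the compounds shown here, three built on one shared core have been tested in a functional assay on CCRF-CEM cells (Homo sapiens) for inhibition, read by sulforhodamine B assay, with a stated time of 48 h, tested at 10 uM (on this read-out higher numbers stand for more inhibition at the one concentration tested (going by the name of the read-out) and lower numbers for less inhibition), and all three carry a different group on the same aromatic carbon of a benzene ring. Compound 1 `c1ccc(-c2cn3ccnc3c(-c3ccc4ncn(C5CCCCC5)c4c3)n2)cc1` gives 81.3%. Compound 2 `Fc1ccc(-c2cn3ccnc3c(-c3ccc4ncn(C5CCCCC5)c4c3)n2)cc1` gives 33.4%, and compound 3 `CC(=O)c1ccc(-c2cn3ccnc3c(-c3ccc4ncn(C5CCCCC5)c4c3)n2)cc1` gives 1.1%, the lowest of the three numbers. The measured steps are a number 47.9 percentage points lower from compound 1 to compound 2 (beyond the scatter), a number 80.2 percentage points lower from compound 1 to compound 3 (beyond the scatter) and a number 32.3 percentage points lower from compound 2 to compound 3 (beyond the scatter).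

Compound 4 `Clc1ccc(-c2cn3ccnc3c(-c3ccc4ncn(C5CCCCC5)c4c3)n2)cc1` differs from compound 3 by chloro in place of acetyl on an aromatic carbon. Among the measured compounds shown here, two measured steps bear on this change, since the acetyl group now leaving was introduced in a number 32.3 percentage points lower from compound 2 to compound 3 (beyond the scatter) and in a number 80.2 percentage points lower from compound 1 to compound 3 (beyond the scatter); both were large drops, so taking the acetyl away is expected to raise the number. Compound 2, which carries fluoro at this position, stands far below compound 1, and chloro is expected to behave more like fluoro than like hydrogen here. A rise from compound 3 toward the level of compound 2 is therefore expected, roughly a number 28.9 percentage points higher from compound 3 to compound 4 (beyond the scatter). Compound 4 is estimated at 30%, within a range from 5% to 60%.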

Compound 4, a percentage reported as inhibition, at one concentration (the size of the read-out at that concentration, not a potency): 11.4%
Estimate against measurement, compound 4: 18.6 percentage points above, within the range that was stated.
By their numbers in this assay, from the lowest: compound 3; then compound 4; then compound 2; then compound 1.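

In this assay the change from 4-acetylphenyl to 4-chlorophenyl gives back only a little, with a number 10.3 percentage points higher from compound 3 to compound 4 (beyond the scatter) as the whole gain. Chloro also stands under fluoro, with a number 22 percentage points lower from compound 2 to compound 4 (beyond the scatter) on this carbon, and well under hydrogen, with a number 69.9 percentage points lower from compound 1 to compound 4 (beyond the scatter) at the same place. A single heavy atom here therefore does not by itself restore the number, and all three groups on this carbon give less inhibition than hydrogen does. Nothing measured here accounts for this order of hydrogen, acetyl, fluoro and chloro. As far as these compounds go, whether any group on this carbon can match or pass hydrogen stays open, for instance an amine, a methoxy group or a carboxylic acid. From the compounds shown here alone, all these groups sit at this one place, para to a large group, so the effect of the same groups elsewhere on the ring also stays open.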